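Swapping the hydroxyphenyl for a nitrophenyl on the hydrazone

This account rests on a few compounds, and the source may have more. Where it says the series, first, only, none or still open, it means among the compounds named here.

Compound 1 `O=C(CCN1CCN(c2ccnc3cc(Cl)ccc23)CC1)N/N=C/c1ccc(Cl)cc1` gives 200 nM in an ADME assay on cells (Splenocyte, Mus musculus, strain BALB/c) for cytotoxicity, read by thymidine incorporation, with a stated time of 24 h; on this read-out lower numbers stand for stronger inhibition and higher numbers for weaker inhibition.
Compound 2 `COc1cc(/C=N/NC(=O)CCN2CCN(c3ccnc4cc(Cl)ccc34)CC2)ccc1OC(C)=O` gives 15800 nM in this assay.
Compound 3 `O=C(CCN1CCN(c2ccnc3cc(Cl)ccc23)CC1)N/N=C/c1ccccc1O` gives 11500 nM in this assay.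

Compound 3 stands second highest of the three numbers, close to compound 2 and far from compound 1, as the step of a 1.4-fold lower number from compound 2 to compound 3 (0.14 log units; within the scatter) and the step of a 58-fold higher number from compound 1 to compound 3 (1.76 log units; beyond the scatter) show. Compound 4 `O=C(CCN1CCN(c2ccnc3cc(Cl)ccc23)CC1)N/N=C/c1ccc([N+](=O)[O-])cc1` changes only the aryl group on the hydrazone carbon: 4-nitrophenyl in place of 2-hydroxyphenyl on a carbon with a double bond to nitrogen. Among the measured steps, a 58-fold higher number from compound 1 to compound 3 (1.76 log units; beyond the scatter) and a 79-fold higher number from compound 1 to compound 2 (1.90 log units; beyond the scatter) are the ones that bear on it: both show that leaving the 4-chlorophenyl for a hydroxy- or acetoxy-bearing aryl raises the number strongly. Compound 4 returns to an aryl without a hydrogen-bond donor, so a lower number is expected, though no nitrophenyl has been measured. The expected step is a 7.7-fold lower number from compound 3 to compound 4 (0.88 log units; beyond the scatter). For compound 4 the estimate in this assay is 1500 nM, between 300 nM and 8000 nM.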

Compound 4, half-maximal inhibitory concentration: 12100 nM
Compound 4: middle estimate off by 8.1-fold (0.91 log units), on the low side; the measured number lies above the stated range.
By their numbers in this assay, from the lowest: compound 1; then compounds 3, 4 and 2 (each within the scatter of the next).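

In this assay the 4-nitrophenyl group sits level with the two oxygen-bearing aryl groups, as a 1.1-fold higher number from compound 3 to compound 4 (0.02 log units; within the scatter) and a 1.3-fold lower number from compound 2 to compound 4 (0.12 log units; within the scatter) show, yet a 61-fold higher number from compound 1 to compound 4 (1.78 log units; beyond the scatter) keeps it far from the 4-chlorophenyl compound. Taking away the hydrogen-bond donor of 2-hydroxyphenyl therefore does not separate compound 4 from compound 3, and among these four compounds only compound 1 stands apart. Nothing measured here explains the gap between chloro and nitro. From the compounds shown here alone, it remains open whether a 4-bromophenyl, a 4-methylphenyl or an unsubstituted phenyl on this carbon with a double bond to nitrogen would behave like compound 1 or like the other three.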